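From cyclobutyl to diethylamino on a sulfonyl sulfur

The source may report more compounds than this note shows. Statements on the series, on what has been measured and on what is new or still open speak of the compounds shown alone.

Compound 1 `CC(C)c1noc(N2CCN(C(=O)[C@@H]3CCCN(S(=O)(=O)c4ccc(S(=O)(=O)C5CCC5)cc4)C3)CC2)n1`: 20 nM
Compound 2 `CCOC(=O)[C@@H]1CCCN(S(=O)(=O)c2ccc(S(=O)(=O)N(CC)CC)cc2C)C1`: 1200 nM
Not yet measured: compound 3 `CCN(CC)S(=O)(=O)c1ccc(S(=O)(=O)N2CCC[C@@H](C(=O)N3CCN(c4nc(C(C)C)no4)CC3)C2)cc1`

In a functional assay on MIA PaCa-2 cells (Homo sapiens) for inhibition, read by MTT assay, with a stated time of 3 days (on this read-out lower numbers stand for stronger inhibition and higher numbers for weaker inhibition), compound 1 holds the lower of the two numbers at 20 nM, which makes it the stronger inhibitor, while compound 2 reads 1200 nM, a gap well beyond the usual scatter.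

Compound 3 keeps the core of compound 1 and alters one group: diethylamino in place of cyclobutyl on a sulfonyl sulfur. In words, diethylamino takes the place of cyclobutyl on a sulfonyl sulfur, so cyclobutylsulfonyl becomes diethylsulfamoyl.

Among the measured compounds shown here, no measured pair shows this change on its own. Compound 2 also carries diethylsulfamoyl and gives 1200 nM, but it differs from compound 1 in other places too, so its number cannot be pinned on that group. Only a small step towards weaker inhibition is therefore expected. The expected move is a 2.3-fold higher number from compound 1 to compound 3 (0.35 log units; beyond the scatter), which may hardly clear the scatter. The estimated value for compound 3 is 45 nM, with an expected range of 12 nM to 200 nM around it.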

Compound 3, half-maximal inhibitory concentration: 30 nM
The estimate for compound 3 lay 1.5-fold (0.18 log units) above the measured number, and the stated range covers the measured number.
By their numbers in this assay, from the lowest: compounds 1 and 3 (each within the scatter of the next); then compound 2.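

In this assay, the swap of cyclobutyl for diethylamino on a sulfonyl sulfur can now be read on its own, in the core of compound 1, and it comes to a 1.5-fold higher number from compound 1 to compound 3 (0.18 log units; within the scatter). On this read-out, then, the two groups cannot be told apart, so in this pair the four-membered carbon ring is not needed for a number in this range, and an open-chain group whose nitrogen sits on the sulfonyl sulfur serves equally well. Nothing measured here explains why the two groups read alike.

Going by these compounds, it remains open how far this position would accept quite different groups, such as a small methyl, a morpholine ring or a carboxylic acid, since cyclobutyl and diethylamino are the only two that can be compared here, and they have the same count of heavy carbon atoms and neither has a hydrogen-bond donor or acceptor. On these data alone, it is also open whether the same swap would read the same way with other parts of the core changed, as a single pair cannot show that.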